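Terminal amide substituent: from compound 2 to compound 3

The source may hold more compounds than are shown below. What is called first, only, known or untested is meant among the compounds shown, and "the series" means these compounds.

Measured so far:
compound 1 `CC(C)(C)c1ccc(C(=O)N2CCC3(CC2)C(=O)N(CC(=O)N2CCC(O)CC2)CN3c2ccccc2)cc1` — 4700 nM
compound 2 `CC(C)(C)c1ccc(C(=O)N2CCC3(CC2)C(=O)N(CC(=O)N2CCNCC2)CN3c2ccccc2)cc1` — 22000 nM

In an assay on HEK293 cells for displacement of a labelled ligand from NPC1-like intracellular cholesterol transporter 1 (Homo sapiens) (a lower number here means a stronger inhibitor, a higher number a weaker inhibitor), compound 2 gives 22000 nM, the higher of the two numbers; compound 1 gives 4700 nM. Within the data shown here, the only measured step, a 4.7-fold higher number from compound 1 to compound 2 (0.67 log units; beyond the scatter), lies beyond the scatter and is modest in size. Compound 3 `CC(C)(C)c1ccc(C(=O)N2CCC3(CC2)C(=O)N(CC(=O)NCCCCCO)CN3c2ccccc2)cc1` carries the change ((5-hydroxypentyl)amino in place of piperazin-1-yl on a carbonyl carbon). That single step bears on it: the entering group, like the group in compound 1, carries a hydroxyl, whereas the leaving group does not. The step from compound 2 to compound 3 is therefore expected to run opposite to the measured step, toward a lower number, and to be of modest size, a 3.1-fold lower number from compound 2 to compound 3 (0.50 log units; beyond the scatter). Compound 3 is estimated at 7000 nM, with a range from 2500 nM to 20000 nM. Whether an open chain behaves like the ring of compound 1 is not known from these two compounds.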

Compound 3, half-maximal inhibitory concentration: 9400 nM
Compound 3: the middle estimate sits 1.3-fold (0.13 log units) below what was measured; measured number inside the range.
By their numbers in this assay, from the lowest: compounds 1 and 3 (each within the scatter of the next); then compound 2.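

In this assay the change to (5-hydroxypentyl)amino on the carbonyl carbon gives a 2.3-fold lower number from compound 2 to compound 3 (0.37 log units; beyond the scatter) and shows that a ring is not needed at this position for a number lower than that of the piperazin-1-yl amide. Set against 4-hydroxypiperidin-1-yl, the same group gives a 2.0-fold higher number from compound 1 to compound 3 (0.30 log units; within the scatter) and so leaves compound 1 and compound 3 indistinguishable here, with or without a ring. Across these three compounds, the two groups that carry a hydroxyl stand together and compound 2, whose group has none, stands apart, with no compound going against this.

Nothing available explains these numbers. Going by these compounds, whether the hydroxyl itself matters stays open: a plain pentyl chain, a shorter or longer hydroxyalkyl chain, or a carboxylic acid at the chain end would separate the hydroxyl's contribution from the chain's.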